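Moving the Nitro Group on the Amide Nitrogen

A few compounds are considered here, and "the series" means these few. Any claim that something is new, unique, unknown or untested is made for them only; others in the source may bear on it.

Measured so far in a functional assay on HCT-116 cells (Homo sapiens) for inhibition, read by MTT assay, with a stated time of 2 days (on this read-out higher numbers stand for weaker inhibition of growth and lower numbers for stronger inhibition of growth), are two compounds.
- compound 1 `Nc1ccccc1NC(=O)CCCNCC(=O)Nc1cccc([N+](=O)[O-])c1` gives 22500 nM
- compound 2 `Nc1ccccc1NC(=O)c1ccc(NCC(=O)Nc2ccc([N+](=O)[O-])cc2)cc1` gives 6500 nM

Of these two, compound 2 has the lower number, and its gap to compound 1 lies beyond the scatter. Compound 3 `Nc1ccccc1NC(=O)c1ccc(NCC(=O)Nc2cccc([N+](=O)[O-])c2)cc1` has 3-nitrophenyl in place of 4-nitrophenyl on an amide-type nitrogen and has no reading yet. For the measured compounds named here, no measured pair shows this change alone, so no shift beyond the scatter is expected in this assay and no direction is favoured. The estimated step of a 1.1-fold higher number from compound 2 to compound 3 (0.03 log units; within the scatter) is expected to stay within the scatter. For compound 3 the expected value is 7000 nM (range 2500 nM to 18000 nM).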

Compound 3, concentration for total growth inhibition: 9000 nM
The estimate for compound 3 lay 1.3-fold (0.11 log units) below the measured number; low and high end bracket the measured number.
By their numbers in this assay, from the lowest: compounds 2 and 3 (each within the scatter of the next); then compound 1.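

For the compounds shown here, exchanging 4-nitrophenyl for 3-nitrophenyl on the amide-type nitrogen gives the first pair that differs in one place, and in this assay it reads as a 1.4-fold higher number from compound 2 to compound 3 (0.14 log units; within the scatter) on the shared core. On this read-out, this position therefore does not separate these two nitrophenyl isomers. No measurement at hand bears on the reason for this result. Open, going by these compounds, is how this position responds when an amine or a carboxylic acid stands in place of the nitro group, or when the nitro group is absent from the phenyl ring.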